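Trimming the benzyl arm of a pyrrolidine ether

The compounds below may be only part of what the source reports. "The series", "measured", "known", "first", "only" and "open" are said of these compounds alone.

Measured compounds:
compound 1 `COc1ccc(CN2CCC[C@H]2COC(c2ccccc2)c2ccc(Cl)cc2)cc1` gives 10000 nM
compound 2 `COc1ccc(CCCN2CCC[C@H]2COC(c2ccccc2)c2ccc(Cl)cc2)cc1` gives 4000 nM

In a functional assay on Jurkat cells (Homo sapiens) for inhibition (a lower number here means a stronger inhibitor, a higher number a weaker inhibitor), compound 2 holds the lowest of the two numbers; its nearest neighbour is compound 1, which sits higher by a 2.5-fold lower number from compound 1 to compound 2 (0.40 log units; beyond the scatter). Compound 3 `CN1CCC[C@H]1COC(c1ccccc1)c1ccc(Cl)cc1` is the unmeasured compound. It differs from compound 2 by hydrogen in place of 2-(4-methoxyphenyl)ethyl on a saturated chain carbon bound to an amine nitrogen in a ring, so the aromatic arm on the ring nitrogen is removed entirely. Among the measured compounds shown here, no measured step covers such a removal. For the measured compounds named here, the only step available, a 2.5-fold lower number from compound 1 to compound 2 (0.40 log units; beyond the scatter), shows that shortening the arm raised the number, and compound 3 goes further in that direction by having no arm at all. A rise at least as large as that step is therefore expected, with wide uncertainty, and it is estimated that compound 3 lies at 12000 nM, between 3000 nM and 40000 nM, meaning an expected step of a 3.0-fold higher number from compound 2 to compound 3 (0.48 log units; beyond the scatter).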

Compound 3, half-maximal inhibitory concentration: 60000 nM
For compound 3 the middle estimate is 5.0-fold (0.70 log units) below the measured one; measured number above the stated range.
By their numbers in this assay, from the lowest: compound 2; then compound 1; then compound 3.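

In this assay, the largest change so far comes from removing the aromatic arm altogether: putting hydrogen in place of 2-(4-methoxyphenyl)ethyl gives a 15-fold higher number from compound 2 to compound 3 (1.18 log units; beyond the scatter) and places compound 3 highest of the set. The shorter arm also matters, since replacing 4-methoxyphenyl at this position with hydrogen gives a 6.0-fold higher number from compound 1 to compound 3 (0.78 log units; beyond the scatter) and the step is beyond the scatter. Among these compounds, having an aromatic arm at all therefore counts for more than its length, although no supporting measurement explains why.

From the compounds shown here alone, it remains open whether the aromatic ring itself matters or whether a plain alkyl chain of the same length would serve as well. Going by these compounds, it is also open whether a longer chain would lower the number further, or how an amine at the end of the arm would change it.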